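The source may hold more compounds than are shown below. What is called first, only, known or untested is meant among the compounds shown, and "the series" means these compounds.

Of the compounds shown here, three built on one shared core have been measured so far. Compound 1 `CC1(C)C=C(n2ccccc2=O)c2cc(S(N)(=O)=O)ccc2O1` gives 69.2 nM in a functional assay with Rattus norvegicus as the target; on this read-out higher numbers stand for an effect only at larger amounts of compound and lower numbers for an effect already at smaller amounts. Compound 2 `CC1(C)C=C(n2ccccc2=O)c2cc(S(=O)(=O)NCCO)ccc2O1` gives 110 nM in this assay, and compound 3 `CC1(C)C=C(n2ccccc2=O)c2cc(S(=O)(=O)N3CCOCC3)ccc2O1` gives 85.1 nM in this assay. On these numbers compound 2 carries the highest value of the three, yet neither gap around it counts as real: the nearer one is a 1.3-fold lower number from compound 2 to compound 3 (0.11 log units; within the scatter), the further one a 1.6-fold higher number from compound 1 to compound 2 (0.20 log units; within the scatter). The remaining step, a 1.2-fold higher number from compound 1 to compound 3 (0.09 log units; within the scatter), is equally within the scatter.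

The unmeasured compound 4 `CC1(C)C=C(n2ccccc2=O)c2cc(S(=O)(=O)Oc3ccccc3)ccc2O1` differs from compound 2 in one place: phenoxy in place of (2-hydroxyethyl)amino on a sulfonyl sulfur. For the measured compounds named here, no measured step covers this exchange. The three known steps swap groups on the sulfonamide nitrogen only, and since all of them stay within the scatter, the evidence points to a position where such changes leave the read-out essentially unmoved. Phenoxy in place of (2-hydroxyethyl)amino goes beyond anything measured, so the expectation rests on that tolerance alone and deserves a wide range. The expected step is a 1.3-fold higher number from compound 2 to compound 4 (0.10 log units; within the scatter), which is no change beyond the scatter. Compound 4 is estimated at 140 nM in this assay, with a range from 35 nM to 600 nM.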

Compound 4, half-maximal effective concentration: 2.51 nM
Compound 4: middle estimate off by 56-fold (1.75 log units), on the high side; measured number outside the range, below it.
By their numbers in this assay, from the lowest: compound 4; then compounds 1, 3 and 2 (each within the scatter of the next).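

The sulfonyl sulfur proves not to be the indifferent place that compound 1, compound 2 and compound 3 made it seem: in this assay, phenoxy in place of the nitrogen-linked groups gives a 44-fold lower number from compound 2 to compound 4 (1.64 log units; beyond the scatter), along with a 34-fold lower number from compound 3 to compound 4 (1.53 log units; beyond the scatter) and a 28-fold lower number from compound 1 to compound 4 (1.44 log units; beyond the scatter). Amino, (2-hydroxyethyl)amino and morpholin-4-yl lie within the scatter of one another, whereas phenoxy stands apart from all three, so this position can respond strongly to the group on the sulfur even though exchanges among those nitrogen-linked groups did not show it. Nothing at hand accounts for the size of these steps.

Phenoxy brings an oxygen link to the sulfur and a six-membered aromatic ring in one exchange, so the compounds shown leave open which of the two goes with the lower number: phenylamino would pair the ring with a nitrogen link, and methoxy would keep the oxygen link without the ring. Also open, as far as these compounds go, is how the read-out responds to further groups at this place, such as benzyloxy or chlorophenoxy.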